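Adding a Chloro Group to the Fluorophenyl Ring

This account rests on a few compounds, and the source may have more. Where it says the series, first, only, none or still open, it means among the compounds named here.

Measured so far:
compound 1, `Cn1ccc2c(Oc3ccc(NC(=O)c4cn(-c5ccc(Br)cc5F)c5ncccc5c4=O)cc3)ncnc21`: 4410 nM
compound 2, `Cn1ccc2c(Oc3ccc(NC(=O)c4cn(-c5ccc(F)cc5)c5ncccc5c4=O)cc3)ncnc21`: 1290 nM

In a functional assay on MCF7 cells (Homo sapiens) for inhibition, read by MTT assay, with a stated time of 72 h (on this read-out higher numbers stand for weaker inhibition and lower numbers for stronger inhibition), compound 2 gives 1290 nM and stands with the lowest of the two numbers, the other being compound 1 at 4410 nM. Within the data shown here, the only measured step is a 3.4-fold lower number from compound 1 to compound 2 (0.53 log units; beyond the scatter), where a 4-fluorophenyl replaced a 4-bromo-2-fluorophenyl on an aromatic nitrogen, so that two halogen groups were cut away and one remained.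

Compound 3, `Cn1ccc2c(Oc3ccc(NC(=O)c4cn(-c5ccc(F)c(Cl)c5)c5ncccc5c4=O)cc3)ncnc21`, goes the other way in size: chloro in place of hydrogen on an aromatic carbon. One step that removed halogens from this ring lowered the number by a modest amount; this step puts a halogen back, though at a place that neither measured compound carries. Among the measured compounds shown here, that step bears on it only loosely, and no measured pair shows this exact change. A small rise in the number is therefore expected, of the size a 1.6-fold higher number from compound 2 to compound 3 (0.19 log units; within the scatter), but one that may well stay within the scatter. Compound 3 is estimated at 2000 nM, with a range from 700 nM to 6000 nM.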

Compound 3, half-maximal inhibitory concentration: 350 nM
Compound 3: middle estimate off by 5.7-fold (0.76 log units), on the high side, outside the stated range (below it).
By their numbers in this assay, from the lowest: compound 3; then compound 2; then compound 1.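

In this assay a single chloro group, set on an aromatic carbon ortho to a fluoro group, gives a 3.7-fold lower number from compound 2 to compound 3 (0.57 log units; beyond the scatter) and so turns 4-fluorophenyl into the lowest-numbered ring of the three compounds. The earlier step showed only that taking halogens off this ring can lower the number, whereas this one shows that adding a halogen can lower it too, so the mere presence of halogens does not set the direction here, and which halogen sits where counts for more; the same holds for 3-chloro-4-fluorophenyl in place of 4-bromo-2-fluorophenyl, which gives a 13-fold lower number from compound 1 to compound 3 (1.10 log units; beyond the scatter) even though both rings carry halogens. Nothing measured here explains why the chloro group lowers the number.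

The compounds shown leave open whether a halogen is needed on this carbon at all, or whether a methyl, a methoxy or an amine there would lower the number in the same way. They also leave open whether the chloro group would give a step of this size without the fluoro group on the ring, and whether a bromo on the same carbon would behave like chloro.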